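From a Limit to an Estimate for Compound 4

A few compounds are considered here, and "the series" means these few. Any claim that something is new, unique, unknown or untested is made for them only; others in the source may bear on it.

Measured in a functional assay on the whole organism with Rattus norvegicus as the target; a higher number here means that more compound is needed for the effect, a lower number that less compound is needed:
- Compound 1 `COc1cc(C)nc(OC)c1NC(=O)N(Cc1ccc(Oc2ccc(F)cc2)cc1)C1CCCCCC1`: 4.5 mg/kg
- Compound 2 `COc1nc(C)cc(SC)c1NC(=O)N(Cc1ccc(Oc2ccc(F)cc2)cc1)C1CCCCCC1`: 1.4 mg/kg
- Compound 3 `Cc1cc(S(C)(=O)=O)c(NC(=O)N(Cc2ccc(Oc3ccc(F)cc3)cc2)C2CCCCCC2)c(Cl)n1`: > 1 mg/kg (a limit, not a number)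

Compound 3 stands only at this limit, so the steps that reach it have no readable size. Compound 4 `Cc1cc(C)c(NC(=O)N(Cc2ccc(Oc3ccc(F)cc3)cc2)C2CCCCCC2)c(C)n1` has not been measured. Its change from compound 3 is a group of 9 heavy atoms (8 carbon, 1 nitrogen; one six-membered aromatic ring with 1 hetero atom) in place of a group of 12 heavy atoms (7 carbon, 1 nitrogen, 2 oxygen, 1 sulfur, 1 chlorine; one six-membered aromatic ring with 1 hetero atom), on an amide-type nitrogen and the group that enters is 2,4,6-trimethylpyridin-3-yl. For the measured compounds named here, the one readable step on this amide-type nitrogen is a 3.2-fold lower number from compound 1 to compound 2 (0.51 log units; beyond the scatter) and it is modest. It gives no direction for this change, so only a modest step is expected, in either direction. The expected change is a step that the limit leaves unreadable from compound 3 to compound 4 and this is only an estimate. Estimated for compound 4 is 2 mg/kg with 0.6 mg/kg to 7 mg/kg as the expected range.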

Compound 4, dose for half-maximal effect: 0.77 mg/kg
Beside the measured number, compound 4's estimate is 2.6-fold (0.41 log units) above it, within the range that was stated.
By their numbers in this assay, from the lowest: compounds 4 and 2 (each within the scatter of the next); then compound 1.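

In this assay, placing 2,4,6-trimethylpyridin-3-yl on this amide-type nitrogen gives a 5.8-fold lower number from compound 1 to compound 4 (0.77 log units; beyond the scatter), so this position needs neither the methoxy nor the methylsulfanyl group for a low dose. Against the methylsulfanyl-bearing group, the change gives a 1.8-fold lower number from compound 2 to compound 4 (0.26 log units; within the scatter), and these two compounds cannot be ordered. Compound 3 is known only by a limit, so only a floor can be given, an at least 1.2-fold lower number from compound 3 to compound 4 (0.11 log units; that floor lies within the scatter), and its steps from compound 1 and compound 2 cannot be read: the limit of > 1 mg/kg in this assay, at which 1 of the 4 values shown sits.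

Which of the three methyl groups matters remains open. So does how an amine, a carboxylic acid or a longer chain would fare in place of a methyl group.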